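Series notes: arylamino in place of aryl on the core

This account rests on a few compounds, and the source may have more. Where it says the series, first, only, none or still open, it means among the compounds named here.

Measured in a functional assay on A549 cells (Homo sapiens) for antiproliferative activity, read by MTT assay, with a stated time of 72 h; a higher number here means a weaker inhibitor, a lower number a stronger inhibitor:
compound 1 `COc1cc(C(=O)c2sc3ccccc3c2-c2ccccc2)cc(OC)c1OC`: 5000 nM
compound 2 `COc1cc(C(=O)c2sc3ccccc3c2-c2ccc(SC)cc2)cc(OC)c1OC`: 5400 nM

Among the compounds with values here, compound 1 has the lower of the two numbers, but its only neighbour is compound 2, and the step of a 1.1-fold higher number from compound 1 to compound 2 (0.03 log units; within the scatter) lies within the scatter, so the two cannot be separated on these data.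

Compound 3 `COc1cc(C(=O)c2sc3ccccc3c2Nc2ccc(C)cc2)cc(OC)c1OC` is not yet measured. Against compound 1 it differs as (4-methylphenyl)amino in place of phenyl on an aromatic carbon. Within the data shown here, the only measured step, from compound 1 to compound 2, adds methylsulfanyl on the aromatic carbon of the phenyl and leaves the link to the core untouched; the change to compound 3 replaces the phenyl itself by a ring joined through a nitrogen bearing a hydrogen. That step therefore bears on the present change only loosely, and it was flat. Among the measured compounds shown here, no measured pair here covers an amino link in place of a direct aryl bond.

With nothing to push the number either way, compound 3 is expected to stay close to compound 1, with an expected step of a 1.1-fold lower number from compound 1 to compound 3 (0.05 log units; within the scatter) and a wide range. The estimate for compound 3 in this assay is 4500 nM, between 1200 nM and 16000 nM.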

Compound 3, half-maximal inhibitory concentration: 2600 nM
Beside the measured number, compound 3's estimate is 1.7-fold (0.24 log units) above it; low and high end bracket the measured number.
By their numbers in this assay, from the lowest: compounds 3, 1 and 2 (each within the scatter of the next, the first and the last beyond it).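

Working notes on the position two ring bonds from the ring sulfur: in this assay, a ring joined through a nitrogen bearing a hydrogen can replace the directly attached phenyl without a change that can be separated from the scatter (a 1.9-fold lower number from compound 1 to compound 3 (0.28 log units; within the scatter)), so a direct aryl bond to the core is not required for activity at this level in compounds 1 and 3. Within the data shown here, in the same assay, this assay, the comparison with the methylsulfanyl-bearing aryl compound gives the only step in this small set that lies beyond the scatter (a 2.1-fold lower number from compound 2 to compound 3 (0.32 log units; beyond the scatter)), though it is modest and rests on a replacement of the entire substituent. No available evidence bears on the origin of either step.

Compound 3 brings the amino link and the 4-methyl group in together, leaving their separate contributions unresolved, and an unsubstituted phenylamino group or a 4-(methylsulfanyl)phenylamino group would be needed to divide them. Also open, going by these compounds, is whether the hydrogen on the link matters, as an N-methyl amine or an ether oxygen in its place would show.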